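Notes on the carbonyl substituent in the series

The source may hold more compounds than are shown below. What is called first, only, known or untested is meant among the compounds shown, and "the series" means these compounds.

Measured so far:
compound 1 `O=C(Nc1c(C(O)(C(F)(F)F)C(F)(F)F)ccc2ccccc12)C1CCCC1` — 495 nM
compound 2 `O=C(CC1CCCC1)Nc1c(C(O)(C(F)(F)F)C(F)(F)F)ccc2ccccc12` — 81 nM
compound 3 `CC(C)OC(=O)Nc1c(C(O)(C(F)(F)F)C(F)(F)F)ccc2ccccc12` — 1160 nM

In an assay on LtK cells with ATP-sensitive inward rectifier potassium channel 11 (Homo sapiens) as the target (on this read-out lower numbers stand for an effect already at smaller amounts and higher numbers for an effect only at larger amounts of compound), compound 1 gives 495 nM, the second highest of the three numbers. Compound 2 sits closest in structure and furthest in value: a 6.1-fold lower number from compound 1 to compound 2 (0.79 log units; beyond the scatter). Compound 3 lies the other way: a 2.3-fold higher number from compound 1 to compound 3 (0.37 log units; beyond the scatter). Between those two outer points, a 14-fold higher number from compound 2 to compound 3 (1.16 log units; beyond the scatter).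

Compound 4 `Cc1cccc(C(=O)Nc2c(C(O)(C(F)(F)F)C(F)(F)F)ccc3ccccc23)c1` has not been measured. Its difference from compound 1 is 3-methylphenyl in place of cyclopentyl on a carbonyl carbon. Both measured steps replace the same cyclopentyl on the carbonyl carbon, so both bear on this one: a carbon-linked, slightly larger group brought a modest gain in compound 2, while an oxygen-linked, smaller group brought a modest loss in compound 3. For the measured compounds named here, the 3-methylphenyl group is carbon-linked and larger than cyclopentyl, which places the expectation on the side of compound 2, though an aromatic ring has no direct precedent here and the expected step is kept small.

Compound 4 is therefore expected to give roughly 300 nM in this assay, within 80 nM to 1200 nM, meaning an expected step of a 1.7-fold lower number from compound 1 to compound 4 (0.22 log units; within the scatter).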

Compound 4, half-maximal effective concentration: 23 nM
For compound 4 the middle estimate is 13-fold (1.12 log units) above the measured one; measured number below the stated range.
By their numbers in this assay, from the lowest: compound 4; then compound 2; then compound 1; then compound 3.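

Working from this assay, the carbonyl carbon takes an aromatic ring with a large gain: 3-methylphenyl in place of cyclopentyl gives a 22-fold lower number from compound 1 to compound 4 (1.33 log units; beyond the scatter), and the same group in place of cyclopentylmethyl still gives a 3.5-fold lower number from compound 2 to compound 4 (0.55 log units; beyond the scatter). Compound 1 and compound 4 both carry a ring directly on this carbonyl carbon, so a directly attached ring does not by itself fix the number, and the lead that compound 2 held over compound 1 no longer marks the best group seen here. The contrast with the oxygen-linked group is wider still, at a 50-fold lower number from compound 3 to compound 4 (1.70 log units; beyond the scatter), and compound 4 now has the lowest number of the four, with all of its steps beyond the scatter, though nothing available explains these differences.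

The step to compound 4 changes the ring type and adds the methyl together, and the compounds shown cannot divide it between the two, as they include no plain phenyl group. As far as these compounds go, how a pyridyl ring, a benzyl group, or a methoxy or chloro group in place of the methyl would read in this assay also remains open.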